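Phenylsulfonyl for phenoxy on the shared core

The source may hold more compounds than are shown below. What is called first, only, known or untested is meant among the compounds shown, and "the series" means these compounds.

Measured: compound 1 `CCOC(=O)c1cnc(C(F)(F)F)nc1NN1C(=O)C=C(C)C1=O`, 1000 nM; compound 2 `CCOC(=O)c1cnc(-c2ccncc2)nc1NN1C(=O)C=C(C)C1=O`, 6000 nM; compound 3 `CCOC(=O)c1cnc(Oc2ccccc2)nc1NN1C(=O)C=C(C)C1=O`, 15000 nM, all in a functional assay on Jurkat cells for inhibition of nuclear factor NF-kappa-B complex (Homo sapiens); a higher number here means a weaker inhibitor, a lower number a stronger inhibitor.

Compound 3 gives the highest number of the three, with a 2.5-fold higher number from compound 2 to compound 3 (0.40 log units; beyond the scatter) and a 15-fold higher number from compound 1 to compound 3 (1.18 log units; beyond the scatter), both beyond the scatter. Compound 4 `CCOC(=O)c1cnc(S(=O)(=O)c2ccccc2)nc1NN1C(=O)C=C(C)C1=O` differs from compound 3 by phenylsulfonyl in place of phenoxy on an aromatic carbon. For the measured compounds named here, no measured step covers a change of this kind; the steps that touch this position, a 6.0-fold higher number from compound 1 to compound 2 (0.78 log units; beyond the scatter) and a 2.5-fold higher number from compound 2 to compound 3 (0.40 log units; beyond the scatter), show only that groups here move the number widely. Compound 4 is therefore expected near compound 3, with a 1.5-fold lower number from compound 3 to compound 4 (0.18 log units; within the scatter), direction uncertain. The estimate for compound 4 in this assay is 10000 nM, between 2000 nM and 50000 nM.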

Compound 4, half-maximal inhibitory concentration: 10000 nM
For compound 4 middle estimate and measured number coincide at the digits printed; the range from low to high includes it.
By their numbers in this assay, from the lowest: compound 1; then compounds 2, 4 and 3 (each within the scatter of the next, the first and the last beyond it).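

In this assay, on this aromatic carbon between two ring nitrogen atoms, phenylsulfonyl and phenoxy cannot be told apart, with a 1.5-fold lower number from compound 3 to compound 4 (0.18 log units; within the scatter) within the scatter, and a 1.7-fold higher number from compound 2 to compound 4 (0.22 log units; within the scatter) also leaves compound 4 within the scatter of the pyridin-4-yl compound, although compounds 2 and 3 differ beyond it. Trifluoromethyl stays clearly apart from phenylsulfonyl, with a 10-fold higher number from compound 1 to compound 4 (1.00 log units; beyond the scatter) beyond the scatter. No evidence on hand bears on this result. As far as these compounds go, what a methyl group, an amine or a carboxylic acid at this position would give stays open, as does whether the low number of compound 1 belongs to trifluoromethyl alone.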